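The source may hold more compounds than are shown below. What is called first, only, known or untested is meant among the compounds shown, and "the series" means these compounds.

Measured in a functional assay on HCT-116 cells (Homo sapiens) for antiproliferative activity, read by MTT assay, with a stated time of 48 h; a lower number here means a stronger inhibitor, a higher number a weaker inhibitor:
compound 1 `COc1ccc(N(C)c2ccnc(Cl)n2)cc1F`: 914 nM
compound 2 `COc1ccc(N(C)c2ccnc(Cl)n2)cc1OCCBr`: 5670 nM
compound 3 `COc1ccc(N(C)c2ccnc(Cl)n2)cc1OCCCCBr`: 1140 nM

The standing of compound 3 rests on two steps. One is a 1.2-fold higher number from compound 1 to compound 3 (0.10 log units; within the scatter), and the other is a 5.0-fold lower number from compound 2 to compound 3 (0.70 log units; beyond the scatter). For the measured compounds named here, its number therefore sits with the first compound of the series and apart from the 2-bromoethoxy member.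

For compound 4 `COc1ccc(N(C)c2ccnc(Cl)n2)cc1OCC[Se]C#N`, the change is a group of 3 heavy atoms (1 carbon, 1 nitrogen, 1 selenium; no ring) in place of a group of 3 heavy atoms (2 carbon, 1 bromine; no ring), on a saturated chain carbon, two bonds along the chain from an oxygen on an aromatic ring, on a saturated chain carbon, two bonds along the chain from an oxygen on an aromatic ring. Going by the values given here, no measured step involves the entering group, so the data fix no direction for this change. The nearest guides are the changes at the same ring position, a 6.2-fold higher number from compound 1 to compound 2 (0.79 log units; beyond the scatter) and the two steps above, and none of these exceeds a modest size. No step beyond the scatter is therefore expected in this assay, although the uncertainty stays wide on both sides.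

For compound 4 the expected value is 700 nM, with an estimated range of 150 nM to 4000 nM. The estimate means an expected 1.6-fold lower number from compound 3 to compound 4 (0.21 log units; within the scatter).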

Compound 4, half-maximal inhibitory concentration: 1220 nM
For compound 4 the middle estimate is 1.7-fold (0.24 log units) below the measured one; measured number inside the range.
By their numbers in this assay, from the lowest: compounds 1, 3 and 4 (each within the scatter of the next); then compound 2.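

On the saturated chain carbon, two bonds along the chain from an oxygen on an aromatic ring, the selenium-containing group takes the place of 2-bromoethyl with no change beyond the scatter in this assay (a 1.1-fold higher number from compound 3 to compound 4 (0.03 log units; within the scatter)). Set against the single bromine of compound 2, the same group gives a real step (a 4.6-fold lower number from compound 2 to compound 4 (0.67 log units; beyond the scatter)), and it stays level with the fluoro compound (a 1.3-fold higher number from compound 1 to compound 4 (0.13 log units; within the scatter)), so compound 2 now stands apart from all three other compounds, and the 4-bromobutoxy chain is no longer the only replacement of fluoro that holds that level. Nothing measured here accounts for these steps.

Open, going by these compounds, is whether the selenium-containing group keeps this level on a longer chain. Also open, on these data alone, is whether an amine or a carboxylic acid at the chain end would do the same.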